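The compounds below may be only part of what the source reports. "The series", "measured", "known", "first", "only" and "open" are said of these compounds alone.

Of the compounds shown here, three built on the shared core have been tested in a functional assay on the whole organism (strain Wistar) for inhibition, with Rattus norvegicus as the target, read by paw edema, with stated times of 60 min and 24 h, at a dose of 100 mg/kg by the oral route; a lower number here means less inhibition, a higher number more inhibition at the dose given (going by the name of the read-out). Compound 1 `COc1cc2c(cc1OC)C(CC(=O)N(C)C)CC2` gives 23.3%, compound 2 `CCCCCNC(=O)CC1CCc2cc(OC)c(OC)cc21` gives 46.7%, and compound 3 `COc1cc2c(cc1OC)C(CC(=O)NC1CCCCC1)CC2` gives 53.3%. Compound 2 stands second highest of the three numbers: its nearest neighbour is compound 3, with the step of a number 6.6 percentage points higher from compound 2 to compound 3 (within the scatter) lying within the scatter, while its furthest is compound 1, with the step of a number 23.4 percentage points higher from compound 1 to compound 2 (beyond the scatter) lying beyond it. Compound 4 `COc1cc2c(cc1OC)C(CC(=O)N1CCCCC1)CC2` is not yet measured and differs from compound 2 in one place: piperidin-1-yl in place of pentylamino on a carbonyl carbon. Among the measured compounds shown here, two measured steps bear on this change. The steps of a number 23.4 percentage points higher from compound 1 to compound 2 (beyond the scatter) and a number 30 percentage points higher from compound 1 to compound 3 (beyond the scatter) both show that moving from dimethylamino to an amino group carrying one hydrogen-bond donor raised the number modestly, and the step of a number 6.6 percentage points higher from compound 2 to compound 3 (within the scatter) shows that a ring in place of a chain on that nitrogen made no difference beyond the scatter. Compound 4 returns to a nitrogen with no hydrogen-bond donor, and a fall is expected for compound 4 because compound 1 with its dimethylamino gives only 23.3%. Compound 4 is therefore estimated at 33% in this assay, within the range 15% to 52%. For the measured compounds named here, the expected step is a number 13.7 percentage points lower from compound 2 to compound 4 (beyond the scatter), a modest fall, though the single comparison behind it leaves the range wide.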

Compound 4, a percentage reported as inhibition, in the whole organism at one dose (the size of the read-out at that dose, not a potency): 40%
Compound 4: middle estimate off by 7 percentage points, on the low side; the measured number falls inside the stated range.
By their numbers in this assay, from the lowest: compound 1; then compounds 4, 2 and 3 (each within the scatter of the next, the first and the last beyond it).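

In this assay, among the compounds shown here, the step of a number 16.7 percentage points higher from compound 1 to compound 4 (beyond the scatter) shows that an amide nitrogen without a hydrogen-bond donor need not stay at the level set by dimethylamino; the earlier compounds could not separate the loss of that donor from the small dimethylamino group itself, since compound 1 was the only donor-free amide among them. The step of a number 6.7 percentage points lower from compound 2 to compound 4 (within the scatter) lies within the scatter, so exchanging the pentylamino chain with its amide hydrogen for the piperidin-1-yl ring without one does not register against that partner. Against the other partner, the step of a number 13.3 percentage points lower from compound 3 to compound 4 (beyond the scatter) lies beyond the scatter, so removing the amide hydrogen cannot be read as a single effect at this position, and the answer depends on which of the two compounds carrying that hydrogen is taken as the reference.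

From the compounds shown here alone, it remains open how a morpholin-4-yl group, a plain amino group or an octylamino chain on this carbonyl carbon would read in this assay next to these four compounds. Nothing among the data given offers an explanation for these steps.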